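Methanesulfonamido in place of methoxycarbonyl: plasma binding outlook

The source may hold more compounds than are shown below. What is called first, only, known or untested is meant among the compounds shown, and "the series" means these compounds.

In an ADME assay on a cell-free system (plasma, Homo sapiens) for protein binding, read by LC-MS, with a stated time of 5 h, tested at 10 uM, compound 1 `OC[C@H]1O[C@H](Oc2ccc(-n3ccc4ccccc43)cc2Cl)[C@@H](O)[C@@H](O)[C@@H]1O` gives 98% and compound 2 `COC(=O)c1ccc2c(ccn2-c2ccc(O[C@H]3O[C@H](CO)[C@@H](O)[C@H](O)[C@@H]3O)c(Cl)c2)c1` gives 99%. Compound 2 stands within the scatter of compound 1, so these numbers do not rank the two. The step to follow leads to compound 3 `CS(=O)(=O)Nc1ccc2c(ccn2-c2ccc(O[C@H]3O[C@H](CO)[C@@H](O)[C@H](O)[C@@H]3O)c(Cl)c2)c1`, with methanesulfonamido in place of methoxycarbonyl on an aromatic carbon. Going by the values given here, one measured step bears on this change: a 2.0-fold lower unbound fraction from compound 1 to compound 2 (0.30 log units; within the scatter), with methoxycarbonyl in place of hydrogen on an aromatic carbon. Among the compounds with values here, no measured compound carries methanesulfonamido, so the evidence is thin. With that single step as the guide, no shift beyond the scatter is expected in this assay. The estimated step is a 1.5-fold higher unbound fraction from compound 2 to compound 3 (0.18 log units; within the scatter). The estimate for compound 3 is 98.5%, with an expected range of 96% to 99.5%.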

Compound 3, plasma protein binding: 94%
For compound 3 the middle estimate is 4.0-fold (0.60 log units) (unbound fraction) below the measured one; the measured number lies below the stated range.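

In this assay, the aromatic carbon of the fused system now shows a change that moves the unbound fraction beyond the scatter, with a 6.0-fold higher unbound fraction from compound 2 to compound 3 (0.78 log units; beyond the scatter) for methanesulfonamido in place of methoxycarbonyl. The shift also holds against hydrogen at the same carbon, with a 3.0-fold higher unbound fraction from compound 1 to compound 3 (0.48 log units; beyond the scatter) for methanesulfonamido in place of hydrogen, whereas methoxycarbonyl in place of hydrogen stayed within the scatter. Nothing measured here accounts for this difference between the two groups.

On these data alone, whether an amine, a carboxylic acid or a longer chain on this carbon would free more of the compound from plasma protein stays open. Also open, as far as these compounds go, is whether methanesulfonamido elsewhere on the shared core would give a step of similar size.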